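Replacing a Secondary Amine with an Ethylpiperazine

The source may report more compounds than this note shows. Statements on the series, on what has been measured and on what is new or still open speak of the compounds shown alone.

Compound 1 `CNCc1c(OC)cc(Oc2cccc(Nc3ccccc3)c2)cc1OC`: 15000 nM
Compound 2 `COc1ccc(CCCNCc2c(OC)cc(Oc3cccc(Nc4ccccc4)c3)cc2OC)cc1`: 6400 nM

In a functional assay on SW-620 cells (Homo sapiens) for inhibition, read by MTT assay, with a stated time of 72 h (a higher number here means a weaker inhibitor, a lower number a stronger inhibitor), compound 1 gives 15000 nM and compound 2 gives 6400 nM. For the measured compounds named here, of the two numbers measured, compound 2 holds the lower one, and the single measured step, a 2.3-fold lower number from compound 1 to compound 2 (0.37 log units; beyond the scatter), is the only change recorded at this part of the molecule.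

Compound 3 `CCN1CCN(Cc2c(OC)cc(Oc3cccc(Nc4ccccc4)c3)cc2OC)CC1` differs from compound 2 by 4-ethylpiperazin-1-yl in place of (3-(4-methoxyphenyl)propyl)amino on a saturated chain carbon bound to an aromatic carbon. Going by the values given here, no measured step replaces the amine in this way, so the step from compound 1 to compound 2 is the only guide: lengthening the substituent on the chain carbon brought a modest gain, and compound 3 gives up that aryl-bearing chain in favour of a ring. The change therefore falls outside what the data directly cover, and a step of modest size in either direction, or none beyond the scatter, remains possible.

Compound 3 is expected to give about 10000 nM, within 3000 nM to 40000 nM. That expectation amounts to a step of a 1.6-fold higher number from compound 2 to compound 3 (0.19 log units; within the scatter).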

Compound 3, half-maximal inhibitory concentration: > 20000 nM
Compound 3 ended at the assay's limit; the forecaster's own chance of this, stated with the estimate: 15%; middle value at least 2.0-fold (0.30 log units) away from the limit.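

In this assay compound 3 stands at a limit and not at a number: the limit of > 20000 nM in this assay, at which 1 of the 3 values shown sits. On the saturated chain carbon bound to an aromatic carbon, 4-ethylpiperazin-1-yl in place of (3-(4-methoxyphenyl)propyl)amino runs against the direction of the earlier step, giving an at least 3.1-fold higher number from compound 2 to compound 3 (0.49 log units; beyond the scatter). In place of methylamino, the same ring gives an at least 1.3-fold higher number from compound 1 to compound 3 (0.12 log units; that floor lies within the scatter), so this ring cannot be set apart from that simpler amine in this assay.

The compounds shown leave open whether the lower number of compound 2 goes with its 4-methoxyphenyl ring or with its amine hydrogen. A piperazine carrying a 3-(4-methoxyphenyl)propyl chain, or a plain propylamine without the aryl ring, would bear on that question.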